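Adding a methyl to the pendant ring of compound 1

The source may hold more compounds than are shown below. What is called first, only, known or untested is meant among the compounds shown, and "the series" means these compounds.

Compound 1 `O=C1CC(c2ccccc2)Oc2ccccc21` gives 2870 nM in an in vitro assay on BTI-TN-5B1-4 cells for inhibition of Amine oxidase [flavin-containing] B (Homo sapiens) (on this read-out higher numbers stand for weaker inhibition and lower numbers for stronger inhibition), where it stands second highest of the three numbers measured; compound 2 `Cc1ccc2c(c1)OC(c1ccccc1)CC2=O` gives 3620 nM and compound 3 `O=C1CC(c2ccc(F)cc2)Oc2cc(F)ccc21` gives 670 nM. Compound 4 `Cc1ccc(C2CC(=O)c3ccccc3O2)cc1` differs from compound 1 in one place: methyl in place of hydrogen on an aromatic carbon. Among the measured compounds shown here, the one comparable step, a 1.3-fold higher number from compound 1 to compound 2 (0.10 log units; within the scatter), put a methyl on the other aromatic ring of the shared core and stayed within the scatter. Nothing measured speaks to a methyl para to the large group, so the expectation for this assay is a step of a 1.0-fold higher number from compound 1 to compound 4 (0.02 log units; within the scatter), which is no change beyond the scatter. Compound 4 is therefore expected to give about 3000 nM, somewhere between 1200 nM and 7500 nM.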

Compound 4, half-maximal inhibitory concentration: 2070 nM
The estimate for compound 4 lay 1.4-fold (0.16 log units) above the measured number, within the range that was stated.
By their numbers in this assay, from the lowest: compound 3; then compounds 4, 1 and 2 (each within the scatter of the next).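

In this assay, a methyl para to a large group produces a 1.4-fold lower number from compound 1 to compound 4 (0.14 log units; within the scatter) and so leaves the number unchanged beyond the scatter. The other methyl, on the other aromatic ring of the shared core, produces a 1.3-fold higher number from compound 1 to compound 2 (0.10 log units; within the scatter) and behaves the same way, so neither of the two sites shown responds to this small addition. Nothing available bears on why the number holds at this position.

On these data alone, whether an amine, a carboxylic acid or a longer chain at this position would shift the number beyond the scatter stays open. Compound 3 differs from compound 1 in more than one place, so its number cannot be assigned to this position alone.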